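Hexylcarbonyl in place of tert-butoxycarbonyl on compound 2

The source may hold more compounds than are shown below. What is called first, only, known or untested is meant among the compounds shown, and "the series" means these compounds.

The three measured compounds share one core bearing a hydroxamic acid and an anilide. Compound 1 `CC(C)(C)OC(=O)Nc1ccc(-c2cc(C(=O)NCc3ccc(C(=O)NO)cc3)no2)cc1` in an assay on Sf9 cells for inhibition of protein deacetylase HDAC6 (Homo sapiens), read by fluorescence, with stated times of 10 min and 2 h (on this read-out higher numbers stand for weaker inhibition and lower numbers for stronger inhibition), gives < 10 nM, which is a limit of the assay and not a number. Compound 2 `CC(C)(C)OC(=O)Nc1cccc(-c2cc(C(=O)NCc3ccc(C(=O)NO)cc3)no2)c1` in this assay gives < 10 nM, again a limit. Compound 3 `CCCCCCC(=O)Nc1ccc(-c2cc(C(=O)NCc3ccc(C(=O)NO)cc3)no2)cc1` in this assay gives < 10 nM, also a limit. Compound 2 therefore stands at the limit. The two further values shown are likewise limits, so no order among the three is readable. The step from compound 1 to compound 3, hexyl in place of tert-butoxy on a carbonyl carbon, reads as a step that the two limits leave unreadable from compound 1 to compound 3 because the limit of < 10 nM in this assay, at which 3 of the 3 values shown sit, is where both its values sit.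

Compound 4 `CCCCCCC(=O)Nc1cccc(-c2cc(C(=O)NCc3ccc(C(=O)NO)cc3)no2)c1` is the unmeasured analogue of compound 2 carrying (hexyl in place of tert-butoxy on a carbonyl carbon). For the measured compounds named here, the only measured step bearing on it is that from compound 1 to compound 3, and its size is not readable; it did not move a value off the limit. The step from compound 2 to compound 4 is therefore expected to be a step that the limit leaves unreadable from compound 2 to compound 4, nothing beyond the scatter. Compound 4 is estimated at 5 nM, with a range from 1.5 nM to 15 nM, and most probably reported again as a limit.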

Compound 4, half-maximal inhibitory concentration: < 10 nM
Compound 4 ended at the assay's limit (the forecaster's own chance of this, stated with the estimate: 75%); the middle value lies beyond the limit too.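

No new step can be read between compound 2 and compound 4, because both sit at the same limit, as do the other two compounds: the limit of < 10 nM in this assay, at which 4 of the 4 values shown sit. The compounds shown leave open whether hexylcarbonyl and tert-butoxycarbonyl differ at all in this assay, and how compound 1, compound 2, compound 3 and compound 4 rank.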